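Adding methoxy to the core of compound 1

The compounds below may be only part of what the source reports. "The series", "measured", "known", "first", "only" and "open" are said of these compounds alone.

Measured in an ADME assay on microsomes from liver (Rattus norvegicus) for metabolic stability; on this read-out lower numbers stand for slow clearance and higher numbers for fast clearance:
- compound 1 (`CC(C)Oc1cc(Oc2ccc(S(C)(=O)=O)cc2)cc(-c2nccc(=O)[nH]2)c1`) gives 105 mL/min/kg as a number
- compound 2 (`CC(C)Oc1cc(Oc2cnc(C(=O)N(C)C)nc2)cc(-c2nccc(=O)[nH]2)c1`) gives < 25.4 mL/min/kg as a limit
- compound 3 (`CCS(=O)(=O)c1ccc(Oc2cc(O[C@@H](C)CO)cc(-c3nccc(=O)[nH]3)c2)cc1`) gives < 25.4 mL/min/kg as a limit

Going by the values given here, compound 1 holds the only true number in this set, 105 mL/min/kg on the fast side of the read-out. The other two results reach no number and are bounded by the limit of < 25.4 mL/min/kg in this assay, at which 2 of the 3 values shown sit, in this set.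

Compound 4 (`COc1cnc(-c2cc(Oc3ccc(S(C)(=O)=O)cc3)cc(OC(C)C)c2)[nH]c1=O`) keeps the rest of compound 1 and carries methoxy in place of hydrogen on an aromatic carbon of the six-membered aromatic ring with 2 nitrogen. The new group sits para to a large group and two atoms from the ring nitrogen.

Among the compounds with values here, no measured pair isolates this change, and compound 2 and compound 3 differ from compound 1 in other places, so neither gives a size for it. The expectation therefore rests on compound 1 at 105 mL/min/kg alone, with no direction favoured. The expected step of a 1.1-fold lower number from compound 1 to compound 4 (0.04 log units; within the scatter) is estimated to stay within the usual scatter of this read-out.

For compound 4 the estimate is 95 mL/min/kg as an expected value, with an expected range from 45 mL/min/kg to 180 mL/min/kg in this assay once measured.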

Compound 4, clearance: < 25.4 mL/min/kg
Compound 4 was reported as a limit; the forecaster's own chance of this, stated with the estimate: 5%; middle value at least 3.7-fold (0.57 log units) from the limit.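

In this assay compound 4 gives < 25.4 mL/min/kg, which is a limit and not a number. Going by these compounds alone, compound 1, compound 2 and compound 3 all carry hydrogen at this position, so methoxy in place of hydrogen on an aromatic carbon, two atoms from the ring nitrogen and para to a large group, is the first change here that can be read on its own, and it gives an at least 4.1-fold lower number from compound 1 to compound 4 (0.61 log units; beyond the scatter). This shows that the position is not silent on this read-out, but the step is a bound rather than a size, and how far the true clearance of compound 4 falls stays unresolved: the limit of < 25.4 mL/min/kg in this assay, at which 3 of the 4 values shown sit.

The compounds shown leave open whether this drop belongs to methoxy itself or would also follow from another group at this position, such as fluorine, methyl or the longer ethoxy chain. They also leave open whether the same change would matter on the other compounds, since compound 2 and compound 3 already stand at a limit in this assay and could show no further fall.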